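Replacing an arylamino group with pyrrolidinyl on a quinone core

This account rests on a few compounds, and the source may have more. Where it says the series, first, only, none or still open, it means among the compounds named here.

Measured so far:
compound 1, `Cc1ccc(NC2=CC(=O)c3c(nc4n3[C@H]3OC[C@@H](O)[C@H]3OC4)C2=O)cc1C`: 1050 nM
compound 2, `O=C1C=C(Nc2ccc(C(F)(F)F)cc2)C(=O)c2c1nc1n2[C@H]2OC[C@@H](O)[C@H]2OC1`: 2820 nM

Two compounds share a core and differ only in the group on a double-bonded ring carbon of the six-membered non-aromatic ring. In a functional assay on MGC-803 cells (Homo sapiens) for inhibition, read by sulforhodamine B assay (on this read-out lower numbers stand for stronger inhibition and higher numbers for weaker inhibition), compound 1 gives 1050 nM. Compound 2 gives 2820 nM, and the gap between the two lies beyond the usual scatter, so compound 1 holds the lower number of the pair.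

Compound 3, `O=C1C(N2CCCC2)=CC(=O)c2c1nc1n2[C@H]2OC[C@@H](O)[C@H]2OC1`, has not yet been measured. It differs from compound 1 in one place: pyrrolidin-1-yl in place of (3,4-dimethylphenyl)amino on a double-bonded ring carbon. Within the data shown here, no measured pair shows the effect of this kind of change, so the expectation rests on the values of compound 1 and compound 2 alone and is uncertain. Compound 3 is expected to give a higher number than compound 1, a step of a 3.3-fold higher number from compound 1 to compound 3 (0.52 log units; beyond the scatter), beyond the scatter. The estimate for compound 3 is 3500 nM, within a range from 900 nM to 14000 nM.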

Compound 3, half-maximal inhibitory concentration: > 16000 nM
Compound 3: a limit, no number; the forecaster's own chance of this, stated with the estimate: 10%; middle value at least 4.5-fold (0.66 log units) from the limit.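

In this assay, compound 3 carries a limit of the assay rather than a number: the limit of > 16000 nM in this assay, at which 1 of the 3 values shown sits.

Even so, the change at this double-bonded ring carbon can be read, and pyrrolidin-1-yl in place of (3,4-dimethylphenyl)amino gives an at least 15-fold higher number from compound 1 to compound 3 (1.18 log units; beyond the scatter). Compound 1 and compound 2 both carry an arylamino group, so they showed only how the number moves from one aryl group to another, whereas compound 3 shows that a group without an arylamino unit can give a far higher number at this position.

The change removes the six-membered aromatic ring and the hydrogen-bond donor together, so the compounds shown cannot separate the two. As far as these compounds go, a cyclohexylamino group, which has the amino hydrogen but no aromatic ring, would bear on that question, and how it would read here remains open.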